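Methyl to Chlorine on a Compound Already at the Limit

The compounds below may be only part of what the source reports. "The series", "measured", "known", "first", "only" and "open" are said of these compounds alone.

Of the compounds shown here, three have so far been tested in a functional assay on KB cells (Homo sapiens) for cytotoxicity; on this read-out lower numbers stand for an effect already at smaller amounts and higher numbers for an effect only at larger amounts of compound. Compound 1 `Cc1ccc2oc(-c3ccccc3)c(O)c(=O)c2c1` gives 2 ug/mL in this assay. Compound 2 `COC1(c2ccccc2)Oc2ccccc2C(=O)C1(O)O` rests on a different core and gives 19 ug/mL in this assay; no single-site change connects it to the others, so its value stands alone. Compound 3 `Cc1ccc2oc(-c3ccccc3)c(Cl)c(=O)c2c1` reports only a limit in this assay, > 100 ug/mL, not a number. As far as these compounds go, compound 3 therefore sits at the limit of > 100 ug/mL in this assay, at which 1 of the 3 values shown sits, and its true value is unknown.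

One step between compounds differing in a single place has been measured: an at least 50-fold higher number from compound 1 to compound 3 (1.69 log units; beyond the scatter), the exchange of a hydroxy for a chloro on an aromatic carbon. It shows that compound 3, the starting point here, already gives an effect only at large amounts, if at all.

Compound 4 `O=c1c(Cl)c(-c2ccccc2)oc2ccc(Cl)cc12` has not been measured. It differs from compound 3 in one place: chloro in place of methyl on an aromatic carbon A methyl leaves and a chloro enters on the six-membered carbon-only ring of the fused system. Among the measured compounds shown here, no measured pair shows this exchange, so the measured step offers no direct guide to its size or direction. Since compound 3 starts at the limit, compound 4 is expected to stay near it, with an estimated 100 ug/mL, ranging from 30 ug/mL to 300 ug/mL. The estimated step of a number no higher from compound 3 to compound 4 (the limit leaves the size open) is expected to be none beyond the scatter.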

Compound 4, concentration for half-maximal effect: > 100 ug/mL
Compound 4: a limit, no number (the forecaster's own chance of this, stated with the estimate: 70%); the middle value lies on the limit itself.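

In this assay compound 4 gives only a limit, > 100 ug/mL, not a number. Compound 3 gives a limit as well, so no step can be read between compound 3 and compound 4: the limit of > 100 ug/mL in this assay, at which 2 of the 4 values shown sit.

The compounds shown leave open whether chloro in place of methyl on an aromatic carbon changes the effect at all.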